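Nitro substitution on two triazole-linked trimethoxyphenyl cores

A few compounds are considered here, and "the series" means these few. Any claim that something is new, unique, unknown or untested is made for them only; others in the source may bear on it.

Compound 1 `COc1cc(-c2ncnn2-c2ccccc2)cc(OC)c1OC` and compound 2 `COc1cc(-n2ncnc2-c2ccccc2)cc(OC)c1OC` are built from the same atoms joined differently; the difference between the two cores is not broken down here. In a functional assay on Jurkat cells (Homo sapiens) for antiproliferative activity, read by MTT assay, with a stated time of 72 h (on this read-out higher numbers stand for weaker inhibition and lower numbers for stronger inhibition), compound 1 reaches only a limit, > 10000 nM. Compound 2 likewise gives a limit in this assay, > 10000 nM. Compound 3 `COc1cc(-n2ncnc2-c2cccc([N+](=O)[O-])c2)cc(OC)c1OC` differs from compound 2 by nitro in place of hydrogen on an aromatic carbon, and in this assay compound 3 also gives a limit, > 10000 nM. The step that the two limits leave unreadable from compound 2 to compound 3 therefore cannot be sized, since every value shown sits at the limit of > 10000 nM in this assay, at which 3 of the 3 values shown sit. Compound 4 `COc1cc(-c2ncnn2-c2cccc([N+](=O)[O-])c2)cc(OC)c1OC` differs from compound 1 by the same change, (nitro in place of hydrogen on an aromatic carbon). For compound 4 the expected step is a step that the limit leaves unreadable from compound 1 to compound 4, resting on the unreadable earlier step. Compound 4 is thus expected to give about 20000 nM in this assay, most likely again only a limit, between 10000 nM and 60000 nM.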

Compound 4, half-maximal inhibitory concentration: > 10000 nM
Compound 4 gave a limit, no number; the forecaster's own chance of this, stated with the estimate: 85%; the middle value does not contradict the limit.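

Compound 4, like compound 1, gives only a limit, so no step can be read between them: the limit of > 10000 nM in this assay, at which 4 of the 4 values shown sit.

The compounds shown leave open whether nitro in place of hydrogen on an aromatic carbon alters inhibition on either core.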